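The source may report more compounds than this note shows. Statements on the series, on what has been measured and on what is new or still open speak of the compounds shown alone.

In a functional assay on T47D cells (Homo sapiens) for antiproliferative activity, read by MTT assay, with a stated time of 72 h (on this read-out higher numbers stand for weaker inhibition and lower numbers for stronger inhibition), compound 1 `CCn1ccnc1-c1cc(OC)c(OC)c(OC)c1` reaches only a limit of the assay, > 100000 nM. Compound 2 `CCCCCn1ccnc1-c1cc(OC)c(OC)c(OC)c1` gives 64400 nM, and compound 3 `COc1cccc(-n2ccnc2-c2cc(OC)c(OC)c(OC)c2)c1` gives 32200 nM, which leaves a 2.0-fold lower number from compound 2 to compound 3 (0.30 log units; within the scatter). Measured against the limit, the aryl compound shows an at least 3.1-fold lower number from compound 1 to compound 3 (0.49 log units; beyond the scatter). Compound 4 `COc1ccc(-n2ccnc2-c2cc(OC)c(OC)c(OC)c2)cc1` keeps the same atoms but joins them differently, with 4-methoxyphenyl in place of 3-methoxyphenyl on an aromatic nitrogen. For the measured compounds named here, no measured step moves a methoxy group, so these steps are only indirect guides, and they suggest changes of modest size. A modest move to a lower number is expected, with wide uncertainty. The expected change is a 2.1-fold lower number from compound 3 to compound 4 (0.33 log units; beyond the scatter). For compound 4 the estimate is 15000 nM, within an expected range of 1500 nM to 70000 nM.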

Compound 4, half-maximal inhibitory concentration: 1400 nM
The estimate for compound 4 lay 11-fold (1.03 log units) above the measured number; the whole stated range lies above it.
By their numbers in this assay, from the lowest: compound 4; then compounds 3 and 2 (each within the scatter of the next). At a limit, above all of these: compound 1.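

Shifting the methoxy group around the phenyl ring on this aromatic nitrogen, with the atoms unchanged, gives a 23-fold lower number from compound 3 to compound 4 (1.36 log units; beyond the scatter), so the place of this one group matters far more than the earlier compounds showed. The replacement of pentyl by 4-methoxyphenyl is also large, with a 46-fold lower number from compound 2 to compound 4 (1.66 log units; beyond the scatter). The ethyl compound reaches only a limit of the assay, so an at least 71-fold lower number from compound 1 to compound 4 (1.85 log units; beyond the scatter) is a floor: the limit of > 100000 nM in this assay, at which 1 of the 4 values shown sits.

As far as these compounds go, whether the gain needs the methoxy group itself stays open. A plain phenyl, 4-hydroxyphenyl or 4-chlorophenyl on this nitrogen would help to settle that.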